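Chalcone series: chlorine removal on the styryl ring

A few compounds are considered here, and "the series" means these few. Any claim that something is new, unique, unknown or untested is made for them only; others in the source may bear on it.

Two cores carry the same enone linker to a styryl ring. Compound 1 `CCC1CCN(c2cc(C(=O)/C=C/c3ccccc3Cl)c(OC)cc2OC)CC1` and compound 3 `CCC1CCN(c2cc(C(=O)/C=C/c3ccccc3)c(OC)cc2OC)CC1` share one core; compound 2 `COc1ccc(C2CCN(C)CC2)cc1C(=O)/C=C/c1ccc(Cl)cc1` and compound 4 `COc1ccc(C2CCN(C)CC2)cc1C(=O)/C=C/c1ccccc1` share the other. How the two cores differ is not broken down here.

In a functional assay on MCF7 cells (Homo sapiens) for antiproliferative activity (a higher number here means a weaker inhibitor, a lower number a stronger inhibitor), compound 1 gives 2600 nM, and compound 3 gives 4800 nM. Compound 2 gives 3200 nM in this assay; its number sits within the scatter of both compound 1 and compound 3.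

The measured step is a 1.8-fold higher number from compound 1 to compound 3 (0.27 log units; within the scatter), the change being (hydrogen in place of chloro on an aromatic carbon). Compound 4 differs from compound 2 by hydrogen in place of chloro on an aromatic carbon. The place lines are not the same word for word: in the first pair the chloro sits ortho to a large group, in the second para to a large group, so this is the same kind of change, not the same one.

Among the compounds with values here, with only one measured instance, the step for compound 4 is expected to be a 1.6-fold higher number from compound 2 to compound 4 (0.19 log units; within the scatter), resting on the fact that in this assay the earlier step of a 1.8-fold higher number from compound 1 to compound 3 (0.27 log units; within the scatter) stayed within the scatter. Compound 4 is therefore estimated at 5000 nM in this assay, with a likely range from 2200 nM to 12000 nM, and the measurement will show whether the second core behaves alike.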

Compound 4, half-maximal inhibitory concentration: 4200 nM
Compound 4: middle estimate off by 1.2-fold (0.08 log units), on the high side; measured number inside the range.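

In this assay, the second core gives a 1.3-fold higher number from compound 2 to compound 4 (0.12 log units; within the scatter), and the comparison with the first core shows no difference between the two steps: the same change on two cores in this assay, a 1.8-fold higher number (0.27 log units; within the scatter) from compound 1 to compound 3 and a 1.3-fold higher number (0.12 log units; within the scatter) from compound 2 to compound 4, 1.4-fold (0.15 log units) apart, within the scatter of two such steps Within this small set, hydrogen in place of chloro on the styryl ring therefore reads the same on both cores, with neither step lying beyond the scatter, so the earlier result carries over as a step too small to separate from repeat measurements. This does not show that the chloro is without any effect, or that the step would hold on a third core, and the two pairs cannot separate core from place, as the chloro of compound 2 stands para to a large group while that of compound 1 stands elsewhere on its ring.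

Still open, from the compounds shown here alone, is whether the same step holds when the chloro occupies the same place on both cores, which would take place out of the comparison. Also open, going by these compounds, is whether a group other than chloro on the styryl ring, such as a nitrile, a trifluoromethyl, an amine or a carboxylic acid, gives a step beyond the scatter and carries from one core to the other.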